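The compounds below may be only part of what the source reports. "The series", "measured", "known", "first", "only" and "open" are said of these compounds alone.

In a functional assay on SK-OV-3 cells (Homo sapiens) for antiproliferative activity, read by MTT assay, with a stated time of 72 h (a higher number here means a weaker inhibitor, a lower number a stronger inhibitor), compound 1 `O=C(CCc1cccc2c1B(O)OC2)Nc1ccccc1` gives 200 nM, compound 2 `O=C(CCc1cccc2c1B(O)OC2)Nc1cccc(Br)c1` gives 540 nM and compound 3 `O=C(CCc1cccc2c1B(O)OC2)Nc1cccc(-c2ccc(F)cc2)c1` gives 93 nM, the lowest of the three numbers. Compound 4 `O=C(CCc1cccc2c1B(O)OC2)Nc1cccc(-c2ccc(Cl)cc2)c1` differs from compound 3 in one place, on an aromatic carbon para to a large group: chloro in place of fluoro on an aromatic carbon. Within the data shown here, no measured step exchanges one halogen for another at this place, so the evidence is indirect. The nearest steps are a 2.7-fold higher number from compound 1 to compound 2 (0.43 log units; beyond the scatter), a 2.2-fold lower number from compound 1 to compound 3 (0.33 log units; beyond the scatter) and a 5.8-fold lower number from compound 2 to compound 3 (0.76 log units; beyond the scatter), all modest, and each involves a larger change than this one. The expected step, a 1.0-fold higher number from compound 3 to compound 4 (0.01 log units; within the scatter), is therefore small, with no direction favoured and nothing expected beyond the scatter. For compound 4 the estimated value is 95 nM, with an expected range of 40 nM to 220 nM.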

Compound 4, half-maximal inhibitory concentration: 220 nM
Compound 4: the middle estimate sits 2.3-fold (0.36 log units) below what was measured, within the range that was stated.
By their numbers in this assay, from the lowest: compound 3; then compounds 1 and 4 (each within the scatter of the next); then compound 2.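

In this assay, chloro in place of fluoro gives a 2.4-fold higher number from compound 3 to compound 4 (0.37 log units; beyond the scatter) and shows that this position, para to a large group, responds to a single halogen exchange. The 4-chlorophenyl group still compares well with bromo, with a 2.5-fold lower number from compound 2 to compound 4 (0.39 log units; beyond the scatter) as the step, but against hydrogen it gives a 1.1-fold higher number from compound 1 to compound 4 (0.04 log units; within the scatter) and so lacks the separation from hydrogen seen with 4-fluorophenyl. No measured evidence here accounts for the difference between fluoro and chloro. As far as these compounds go, whether a methoxy group or an amine at this place would track fluoro or chloro remains open.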